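The compounds below may be only part of what the source reports. "The series", "measured", "known", "first", "only" and "open" are said of these compounds alone.

Compound 1 `COc1cc(CNC(=S)NCC(COC(=O)C(C)(C)C)Cc2ccc(C(C)(C)C)cc2)c(Br)cc1O` and compound 2 `COc1cc(CNC(=S)NCC(COC(=O)C(C)(C)C)Cc2ccc(C(C)(C)C)cc2)c(I)cc1O` differ in one place only. In an assay on CHO cells for displacement of a labelled ligand from transient receptor potential cation channel subfamily V member 1 (Rattus norvegicus) (a higher number here means a weaker inhibitor, a lower number a stronger inhibitor), compound 1 gives 12.8 nM, and compound 2 gives 13.3 nM. The change between them is iodo in place of bromo on an aromatic carbon, and it made a 1.0-fold higher number from compound 1 to compound 2 (0.02 log units; within the scatter), so the two numbers cannot be told apart.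

Compound 3 `COc1cc(CNC(=S)NCC(COC(=O)C(C)(C)C)Cc2ccc(C)c(C)c2)cc(Br)c1O` is built on a different core; how its core differs from that of compound 1 is not broken down here. In this assay compound 3 gives 33.1 nM, a higher number than compound 1 or compound 2, and both of those gaps lie beyond the scatter.

Compound 4 `COc1cc(CNC(=S)NCC(COC(=O)C(C)(C)C)Cc2ccc(C)c(C)c2)cc(I)c1O` has not been measured yet. It stands to compound 3 as compound 2 stands to compound 1: iodo in place of bromo on an aromatic carbon. This is the same kind of change, not the same change, since the surroundings differ. In compound 1 the halogen sits ortho to a large group, meta to a hydroxy group and para to a methoxy group, whereas in compound 3 it sits ortho to a hydroxy group, meta to a large group and meta to a methoxy group.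

For the measured compounds named here, the one measured instance of this swap, the step of a 1.0-fold higher number from compound 1 to compound 2 (0.02 log units; within the scatter), stayed within the scatter, and on that basis compound 4 is expected to show a step of a 1.0-fold higher number from compound 3 to compound 4 (0.01 log units; within the scatter). Compound 4 is therefore estimated at 34 nM, with a likely range from 20 nM to 58 nM.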

Compound 4, inhibition constant: 232 nM
Beside the measured number, compound 4's estimate is 6.8-fold (0.83 log units) below it; measured number outside the range, above it.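

In this assay, putting iodo in place of bromo on the core of compound 3 gave a 7.0-fold higher number from compound 3 to compound 4 (0.85 log units; beyond the scatter), a clear loss of binding strength, whereas the same swap on the core of compound 1 gave a 1.0-fold higher number from compound 1 to compound 2 (0.02 log units; within the scatter), which is no measurable change. A result for this swap on one core therefore could not be carried over to the other, and the two cores gave different answers: the same change on two cores in this assay, a 1.0-fold higher number (0.02 log units; within the scatter) from compound 1 to compound 2 and a 7.0-fold higher number (0.85 log units; beyond the scatter) from compound 3 to compound 4, 6.7-fold (0.83 log units) apart, beyond the scatter of two such steps. For the compounds shown here, this shows that the effect of the swap depends on its surroundings, but with only two pairs of compounds, and with cores that differ in more than one place, it does not show which difference between the cores matters or what lies behind the larger step.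

The compounds shown leave open whether the larger step follows the halogen when it sits ortho to a hydroxy group or follows some other part of the core of compound 3. They also leave open how a chloro group or a plain hydrogen in that same place would compare with bromo and iodo on each core.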